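This account rests on a few compounds, and the source may have more. Where it says the series, first, only, none or still open, it means among the compounds named here.

The measured compounds:
Compound 1, `O=c1[nH]cnc2c1c(-c1ccoc1)cn2[C@@H]1O[C@H](CO)[C@@H](O)[C@H]1O`, gives 10300 nM in a functional assay on HCT-116 cells (Homo sapiens), read by MTT assay, with a stated time of 72 h; a lower number here means a stronger inhibitor, a higher number a weaker inhibitor.
Compound 2, `O=c1[nH]cnc2c1c(-c1ccsc1)cn2[C@@H]1O[C@H](CO)[C@@H](O)[C@H]1O`, gives > 20000 nM, which is a limit of this assay rather than a number.
Compound 3, `CNc1ncnc2c1c(-c1ccsc1)cn2[C@@H]1O[C@H](CO)[C@@H](O)[C@H]1O`, gives > 20000 nM, again a limit rather than a number.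

Compound 4, `CNc1ncnc2c1c(-c1ccoc1)cn2[C@@H]1O[C@H](CO)[C@@H](O)[C@H]1O`, is not yet measured. It differs from compound 3 by furan-3-yl in place of thiophen-3-yl on an aromatic carbon. The same change is made from compound 2 to compound 1, (furan-3-yl in place of thiophen-3-yl on an aromatic carbon), and it produced an at least 1.9-fold lower number from compound 2 to compound 1 (0.28 log units; that floor lies within the scatter). The two "place:" descriptions are identical word for word, so this is the same change in both pairs; how the core of compound 2 differs from that of compound 3 is not broken down here. Because compound 2 sits at the limit of > 20000 nM in this assay, at which 2 of the 3 values shown sit, only a floor is known for that earlier step. For compound 4 a step of similar size is expected, an at least 1.4-fold lower number from compound 3 to compound 4 (0.15 log units; that floor lies within the scatter), resting on an at least 1.9-fold lower number from compound 2 to compound 1 (0.28 log units; that floor lies within the scatter), and with compound 3 itself at a limit the outcome may again be a limit. Compound 4 is therefore estimated at 14000 nM, between 4500 nM and 45000 nM.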

Compound 4, half-maximal inhibitory concentration: > 20000 nM
Compound 4: only a limit was reported; the forecaster's own chance of this, stated with the estimate: 50%; middle value at least 1.4-fold (0.15 log units) from the limit.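

No step can be read from compound 3 to compound 4, because both compounds stop at the same limit rather than giving a number: the limit of > 20000 nM in this assay, at which 3 of the 4 values shown sit.

The compounds shown leave open whether furan-3-yl in place of thiophen-3-yl on the core of compound 3 changes the number at all, and by how much.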